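A few compounds are considered here, and "the series" means these few. Any claim that something is new, unique, unknown or untested is made for them only; others in the source may bear on it.

The series shares one core, shown by compound 2 `CCO/C(O)=C1\C(COCCN2CC(=O)NC2=O)=NC(C)=C(C(=O)OC)C1c1ccccc1Cl`, and is read in a functional assay (aorta) with Rattus norvegicus as the target; a lower number here means a stronger inhibitor, a higher number a weaker inhibitor. Going by the values given here, compound 2 gives 20 nM, the second highest of the three numbers so far. Compound 3 `CCO/C(O)=C1\C(COCCn2cc(N)nc2O)=NC(C)=C(C(=O)OC)C1c1ccccc1Cl`, which carries a different ring on the chain, gives 31.6 nM; the step of a 1.6-fold higher number from compound 2 to compound 3 (0.20 log units; within the scatter) stays within the scatter. Compound 1 `CCO/C(O)=C1\C(COCCN2CC(=O)N(C)C2=O)=NC(C)=C(C(=O)OC)C1c1cccc(Cl)c1Cl` gives 5.01 nM, the lowest of the three numbers, but compound 1 differs from compound 2 in two places, on the ring nitrogen and on the aryl, so its value alone does not tell what either change is worth.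

Compound 4 `CCO/C(O)=C1\C(COCCN2CC(=O)N(C)C2=O)=NC(C)=C(C(=O)OC)C1c1ccccc1Cl` is the next member. The change from compound 2 is methyl in place of hydrogen on an amide-type nitrogen in a ring. Among the compounds with values here, no measured step tests this change on its own; the only measured step, to compound 3, swaps the whole ring and stays within the scatter. Compound 1 bears the same methyl and gives 5.01 nM, which leans the expectation toward a somewhat lower rather than a higher number, though the aryl also differs there. For compound 4 the expected step is a 1.5-fold lower number from compound 2 to compound 4 (0.19 log units; within the scatter), not beyond the scatter. Compound 4 is thus estimated at 13 nM, within a range of 4 nM to 40 nM.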

Compound 4, half-maximal inhibitory concentration: 25.1 nM
Estimate against measurement, compound 4: 1.9-fold (0.29 log units) below; measured number inside the range.
By their numbers in this assay, from the lowest: compound 1; then compounds 2, 4 and 3 (each within the scatter of the next).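

In this assay the methyl on the amide-type nitrogen in a ring, now isolated as a single change, gives a 1.3-fold higher number from compound 2 to compound 4 (0.10 log units; within the scatter) and so has no readable effect at this position of the 2,4-dioxoimidazolidin-1-yl ring. Going by these compounds alone, the whole-ring swap gives a 1.3-fold lower number from compound 3 to compound 4 (0.10 log units; within the scatter) and likewise separates nothing, so the 3-methyl-2,4-dioxoimidazolidin-1-yl and 4-amino-2-hydroxy-1H-imidazol-1-yl groups on the chain cannot be told apart here, whereas hydrogen in place of chloro on an aromatic carbon gives a 5.0-fold higher number from compound 1 to compound 4 (0.70 log units; beyond the scatter) and is the only new step beyond the scatter, which places the low number of compound 1 with the extra chloro and not with the methyl. No measured evidence bearing on the reason for any of these steps is at hand.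

As far as these compounds go, whether an ethyl or a benzyl on the same amide-type nitrogen would also leave the number unmoved remains open. Also open, from the compounds shown here alone, are whether the chloro step holds on a ring without the methyl and whether a fluoro or a methoxy at that aromatic carbon would match the chloro.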